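The source may report more compounds than this note shows. Statements on the series, on what has been measured and on what is new or still open speak of the compounds shown alone.

Three compounds of the series have been run in a functional assay on MCF7 cells (Homo sapiens) for antiproliferative activity, read by sulforhodamine B assay, with a stated time of 48 h; a lower number here means a stronger inhibitor, a higher number a weaker inhibitor. Compound 1 `CCCCCCOc1ccc(NS(=O)(=O)c2ccc(N3CCNC3=O)cc2)cc1` returns only a limit, > 1000 nM. Compound 2 `CC(C)(C)c1ccc(NS(=O)(=O)c2ccc(N3CCNC3=O)cc2)cc1` likewise returns only a limit, > 1000 nM. Among the compounds with values here, the single step between measured compounds, a step that the two limits leave unreadable from compound 1 to compound 2, is unreadable for that reason. Within the data shown here, compound 3 `Cc1ccc(NS(=O)(=O)c2ccc(N3CCNC3=O)cc2)c(C)c1` gives 230 nM, the only number in the set so far. The other two values rest at the limit of > 1000 nM in this assay, at which 2 of the 3 values shown sit. Compound 4 `Cc1ccc(NS(=O)(=O)c2ccc(N3CCNC3=O)cc2)cc1` differs from compound 3 by hydrogen in place of methyl on an aromatic carbon. Among the measured compounds shown here, no measured step concerns a methyl on this ring, so no size is borrowed from elsewhere in the set. For compound 4 a small loss, close to the usual scatter, is expected, a 1.7-fold higher number from compound 3 to compound 4 (0.24 log units; within the scatter). Compound 4 is estimated at 400 nM, within 150 nM to 1500 nM.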

Compound 4, half-maximal inhibitory concentration: 610 nM
Compound 4: middle estimate off by 1.5-fold (0.18 log units), on the low side; low and high end bracket the measured number.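

In this assay, within the data shown here, the methyl ortho to a large group carries a readable share of the activity: a 2.7-fold higher number from compound 3 to compound 4 (0.42 log units; beyond the scatter), the first sized step. Against the two weaker compounds the steps are an at least 1.6-fold lower number from compound 2 to compound 4 (0.21 log units; that floor lies within the scatter) and an at least 1.6-fold lower number from compound 1 to compound 4 (0.21 log units; that floor lies within the scatter), so methyl in place of tert-butyl or hexyloxy has no firm size yet, and both steps are floors only: the limit of > 1000 nM in this assay, at which 2 of the 4 values shown sit.

Open, on these data alone, is whether ethyl, methoxy or chlorine ortho to the large group would hold what this methyl gives. Also open, as far as these compounds go, is whether the methyl of the 4-methylphenyl group is needed at all.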